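This account rests on a few compounds, and the source may have more. Where it says the series, first, only, none or still open, it means among the compounds named here.

Compound 1 `Oc1ccc(-c2cc(-c3cccs3)cc(-c3ccccc3O)n2)cc1` gives 72.2% in an assay on isolated protein for inhibition of DNA topoisomerase 1 (Homo sapiens), with a stated time of 30 min, tested at 100 uM; a lower number here means a weaker effect, a higher number a stronger effect of the compound at the concentration tested.
Compound 2 `Oc1ccc(-c2cc(-c3ccsc3)cc(-c3ccccc3O)n2)cc1` gives 13.8% in this assay.
Compound 3 `Oc1ccc(-c2cc(-c3ccsc3)cc(-c3cccc(O)c3)n2)cc1` gives 17.1% in this assay.

On these three numbers compound 2 stands lowest. Its nearest neighbour is compound 3, reached by a number 3.3 percentage points higher from compound 2 to compound 3 (within the scatter), a step within the scatter. Compound 1 lies furthest away: the change to thiophen-3-yl in place of thiophen-2-yl on an aromatic carbon brought a number 58.4 percentage points lower from compound 1 to compound 2 (beyond the scatter), a large step beyond the scatter.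

The next compound to be considered is compound 4 `Oc1ccc(-c2cc(-c3ccco3)cc(-c3ccccc3O)n2)cc1`. It differs from compound 2 in one place: furan-2-yl in place of thiophen-3-yl on an aromatic carbon. Among the measured compounds shown here, of the measured steps only the one from compound 1 to compound 2 bears on this change, since it too exchanges the five-membered aromatic ring on the same carbon, and it was large. The step from compound 2 to compound 3 concerns a hydroxyphenyl group and says nothing here. Because a number 58.4 percentage points lower from compound 1 to compound 2 (beyond the scatter) shows that moving from a ring attached at its second position to one attached at its third position lost most of the inhibition, a ring again attached at its second position, furan-2-yl, is expected to regain part of that loss, though the oxygen in place of sulfur leaves the size uncertain. For compound 4 the step is therefore expected to be a number 26.2 percentage points higher from compound 2 to compound 4 (beyond the scatter), upward and beyond the scatter. Compound 4 is estimated to give 40% in this assay, within a range from 10% to 75%.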

Compound 4, a percentage reported as inhibition, at one concentration (the size of the read-out at that concentration, not a potency): 83%
Beside the measured number, compound 4's estimate is 43 percentage points below it, outside the stated range (above it).
By their numbers in this assay, from the lowest: compounds 2 and 3 (each within the scatter of the next); then compound 1; then compound 4.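

On the carbon opposite the ring nitrogen, the five-membered ring decides nearly everything, and the result shows that the large loss seen with thiophen-3-yl can be fully reversed: furan-2-yl gives a number 69.2 percentage points higher from compound 2 to compound 4 (beyond the scatter). Exchanging sulfur for oxygen in a ring attached in the same way costs nothing in this assay, since furan-2-yl gives a number 10.8 percentage points higher from compound 1 to compound 4 (beyond the scatter), a modest step that is still beyond the scatter, so among these compounds thiophen-2-yl and furan-2-yl both stand high while thiophen-3-yl stands low. Nothing available here explains why these closely matched rings, which have the same counts of heavy atoms and hydrogen-bond acceptors, differ so widely.

On these data alone, what remains open is whether the attachment point or the ring atom matters more, a question that furan-3-yl, the one ring completing the set, or a pyrrol-2-yl ring carrying a nitrogen would address on the same core. As far as these compounds go, it also remains open whether furan-2-yl keeps this level beside a 3-hydroxyphenyl group, as in compound 3, and whether a six-membered ring such as pyridin-2-yl or a simple amine would be accepted on this carbon at all.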